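Swapping the aryl ring of a thiosemicarbazone for thiophene

The source may hold more compounds than are shown below. What is called first, only, known or untested is meant among the compounds shown, and "the series" means these compounds.

Measured so far in a functional assay on U-251 cells (Homo sapiens) for inhibition, read by sulforhodamine B assay, with a stated time of 48 h; a higher number here means a weaker inhibitor of growth, a lower number a stronger inhibitor of growth:
compound 1, `CC1=CC[C@H](C(C)(C)N=C=S)CC1`, 29100 nM
compound 2, `COc1ccc(/C=N/NC(=S)NC(C)(C)[C@H]2CC=C(C)CC2)cc1`, 11400 nM
compound 3, `CC1=CC[C@H](C(C)(C)NC(=S)N/N=C/c2ccc(F)cc2)CC1`, a limit of the assay, > 100000 nM

Compound 2 has the lowest of the two numbers, with compound 1 the nearest at a higher value. For compound 3 the assay gives only a limit, (the limit of > 100000 nM in this assay, at which 1 of the 3 values shown sits), and no number.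

Compound 4, `CC1=CC[C@H](C(C)(C)NC(=S)N/N=C/c2cccs2)CC1`, has not yet been measured. It differs from compound 2 in one place: thiophen-2-yl in place of 4-methoxyphenyl on a carbon with a double bond to nitrogen.

One measured step speaks to this change. Removing the methoxy by replacing it with fluoro gave an at least 8.7-fold higher number from compound 2 to compound 3 (0.94 log units; beyond the scatter). Compound 4 also loses the 4-methoxyphenyl, so a weaker inhibitor than compound 2 is expected, though the thiophen-2-yl ring is a larger change than a single swap on the ring, and the step may fall short of that seen with compound 3.

For compound 4 the expected step is a 3.9-fold higher number from compound 2 to compound 4 (0.60 log units; beyond the scatter). Compound 4 is therefore estimated at 45000 nM, with a range from 15000 nM to 130000 nM.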

Compound 4, concentration for 50% growth inhibition: 13500 nM
Compound 4: the middle estimate sits 3.3-fold (0.52 log units) above what was measured; measured number below the stated range.
By their numbers in this assay, from the lowest: compounds 2 and 4 (each within the scatter of the next); then compound 1. At a limit, above all of these: compound 3.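

In this assay, thiophen-2-yl in place of 4-methoxyphenyl gives a 1.2-fold higher number from compound 2 to compound 4 (0.07 log units; within the scatter) and so keeps the growth inhibition of compound 2, even though the new ring is five-membered, holds sulfur and has fewer heavy atoms. Losing the 4-methoxyphenyl therefore does not by itself weaken these compounds, as thiophen-2-yl in place of 4-fluorophenyl gives an at least 7.4-fold lower number from compound 3 to compound 4 (0.86 log units; beyond the scatter) and shows that the weak result belongs to the 4-fluorophenyl compound, not to every replacement on this carbon with a double bond to nitrogen. Compound 3 stands at a limit and not a number, so that step gives only a lower bound: the limit of > 100000 nM in this assay, at which 1 of the 4 values shown sits.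

Going by these compounds, it remains open whether the sulfur of thiophen-2-yl matters, which furan-2-yl or plain phenyl on this carbon would test. On these data alone, it is also open whether 4-hydroxyphenyl or 4-chlorophenyl would behave like compound 2 or like compound 3.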